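The compounds below may be only part of what the source reports. "The series", "measured", "known", "first", "only" and "open" are said of these compounds alone.

Measured so far in a functional assay on DU-145 cells (Homo sapiens) for cytotoxicity, read by sulforhodamine B assay, with a stated time of 48 h; on this read-out lower numbers stand for stronger inhibition of growth and higher numbers for weaker inhibition of growth:
Compound 1 `COc1ccc(CN2CCN(c3nc(Nc4ccc(C#N)c(C(F)(F)F)c4)nc(Oc4ccnc5ccccc45)n3)CC2)c(OC)c1OC` gives only a limit, > 100000 nM.
Compound 2 `N#Cc1ccc(Nc2nc(Oc3ccnc4ccccc34)nc(N3CCN(c4ccccc4F)CC3)n2)cc1C(F)(F)F` gives only a limit, > 100000 nM.
Compound 3 `N#Cc1ccc(Nc2nc(Oc3ccnc4ccccc34)nc(N3CCN(c4ccccn4)CC3)n2)cc1C(F)(F)F` gives 85900 nM.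

Compound 2 thus stands at the limit of this assay, as does compound 1 (the limit of > 100000 nM in this assay, at which 2 of the 3 values shown sit). Within the data shown here, the only measured step that starts from compound 2 is an at least 1.1-fold lower number from compound 2 to compound 3 (0.06 log units; that floor lies within the scatter), a step that stays within the scatter. Compound 4 `N#Cc1ccc(Nc2nc(Oc3ccnc4ccccc34)nc(N3CCN(c4ccc(F)cc4)CC3)n2)cc1C(F)(F)F` differs from compound 2 by 4-fluorophenyl in place of 2-fluorophenyl on an amine nitrogen in a ring. Among the measured compounds shown here, no measured step exchanges one fluorophenyl for another, so nothing in the numbers points to a shift beyond the scatter in this assay. Compound 4 is therefore expected to remain at or near the limit, with an expected step of a number no higher from compound 2 to compound 4 (the limit leaves the size open). The estimate for compound 4 is 100000 nM, with a range from 40000 nM to 300000 nM.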

Compound 4, concentration for 50% growth inhibition: > 100000 nM
Compound 4: only a limit was reported; the forecaster's own chance of this, stated with the estimate: 60%; the middle value lies on the limit itself.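

In this assay, the exchange of 2-fluorophenyl for 4-fluorophenyl on the amine nitrogen in the ring cannot be read, since compound 2 and compound 4 both sit at a limit. Against pyridin-2-yl, 4-fluorophenyl at this place gives an at least 1.1-fold higher number from compound 3 to compound 4 (0.06 log units; that floor lies within the scatter). A second fluorophenyl thus joins the compounds that reach no measurable value here: the limit of > 100000 nM in this assay, at which 3 of the 4 values shown sit.

The limit leaves any order among compound 1, compound 2 and compound 4 unknown. On these data alone, whether an acetyl group or a longer alkyl chain on that amine nitrogen would bring a value clear of the limit stays open.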